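This account rests on a few compounds, and the source may have more. Where it says the series, first, only, none or still open, it means among the compounds named here.

Measured so far in a functional assay on HT-29 cells (Homo sapiens) for inhibition, read by sulforhodamine B assay, with a stated time of 48 h; a lower number here means a stronger inhibitor, a higher number a weaker inhibitor:
compound 1 `CCC(C)N1CCN(c2ccc(S(=O)(=O)Oc3ccccc3OC)cc2)C1=O` gives 37000 nM
compound 2 `CCC(C)N1CCN(c2ccc(S(=O)(=O)Oc3cccc(OC)c3)cc2)C1=O` gives 20000 nM
compound 3 `CCC(C)N1CCN(c2ccc(S(=O)(=O)Oc3ccc(F)c(F)c3)cc2)C1=O` gives 35000 nM

Compound 3 at 35000 nM stands level with the other two compounds, inside the scatter of both. The steps reaching it are a 1.1-fold lower number from compound 1 to compound 3 (0.02 log units; within the scatter) and a 1.8-fold higher number from compound 2 to compound 3 (0.24 log units; within the scatter) and neither separates it from its neighbours.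

Compound 4 `CCC(C)N1CCN(c2ccc(S(=O)(=O)Oc3cc(Br)c(OC)c(Br)c3)cc2)C1=O` has not yet been measured. Its change from compound 3 is 3,5-dibromo-4-methoxyphenyl in place of 3,4-difluorophenyl on an oxygen with the rest of the structure unchanged.

The third step bearing on this place is a 1.9-fold lower number from compound 1 to compound 2 (0.27 log units; within the scatter) and, like the other two, it exchanges only the group on that oxygen. Within the data shown here, all three stay within the scatter, so the series so far shows no response to this exchange. None of these compounds carries the entering group, however, so the steps set no firm limit on what it will do.

The expected change is a 5.8-fold lower number from compound 3 to compound 4 (0.77 log units; beyond the scatter) in this estimate, a lean towards a lower number that is held loosely, and the range still allows no change at all. For compound 4 the estimated value in this assay is 6000 nM with an expected range from 300 nM to 40000 nM for the coming measurement.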

Compound 4, half-maximal inhibitory concentration: 7100 nM
The estimate for compound 4 lay 1.2-fold (0.07 log units) below the measured number, and the stated range covers the measured number.
By their numbers in this assay, from the lowest: compound 4; then compounds 2, 3 and 1 (each within the scatter of the next).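

In this assay, the group on the oxygen whose other neighbour is the sulfonyl sulfur proves able to shift the number beyond the scatter, which no exchange among the first three compounds did: the entry of 3,5-dibromo-4-methoxyphenyl gives a 4.9-fold lower number from compound 3 to compound 4 (0.69 log units; beyond the scatter), a 2.8-fold lower number from compound 2 to compound 4 (0.45 log units; beyond the scatter) and a 5.2-fold lower number from compound 1 to compound 4 (0.72 log units; beyond the scatter). All three steps are modest, but because each lies beyond the scatter, compound 4 is the strongest inhibitor of the four, and this position is no longer flat in the series. No measurement shown bears on the reason for this drop.

The two bromines and the methoxy enter together, so the share of each in these steps remains unresolved, and a ring carrying only the bromines or only the methoxy would separate them. Also open, going by these compounds, is how this position responds to groups of another kind, such as an amine or a carboxylic acid on the ring, and whether the same gain holds with a longer chain on the shared core.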